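Carboxyethyl to dihydroxyethyl: working notes on the series

The compounds below may be only part of what the source reports. "The series", "measured", "known", "first", "only" and "open" are said of these compounds alone.

In an ADME assay on the whole organism (Rattus norvegicus) for pharmacokinetics, using cassette dosing, at a dose of 1 mg/kg by the oral route (a lower number here means that a smaller share of the oral dose reaches the circulation, a higher number that a larger share of the oral dose reaches the circulation), compound 1 (`Cc1ccc(Cn2c(=O)n(CC(C)(C)C(=O)O)c(=O)[nH]/c2=N\c2ccc(OC(C)C)c(Cl)c2)cc1`) gives 30.7%, compound 2 (`CC(C)Oc1ccc(/N=c2\[nH]c(=O)n(C[C@@H](C)C(=O)O)c(=O)n2Cc2ccc(Cl)cc2)cc1Cl`) gives 108% and compound 3 (`Cc1cc(/N=c2\[nH]c(=O)n(C[C@H](C)C(=O)O)c(=O)n2Cc2ccc(Cl)cc2)ccc1OC(C)C`) gives 102%. Compound 2 stands level with compound 3 within the scatter, and beyond the scatter above compound 1.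

Compound 4 (`CC(C)Oc1ccc(/N=c2\[nH]c(=O)n(C[C@@H](O)CO)c(=O)n2Cc2ccc(Cl)cc2)cc1Cl`) differs from compound 2 by 1,2-dihydroxyethyl in place of 1-carboxyethyl on a saturated chain carbon bound to an aromatic nitrogen. Going by the values given here, no measured pair isolates this change, so the expectation in this assay is loosely founded. The expected a number 48 percentage points lower from compound 2 to compound 4 (beyond the scatter) points downward, beyond the scatter. For compound 4 the estimated value is 60%, with an expected range of 25% to 100%.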

Compound 4, oral bioavailability: 63%
For compound 4 the middle estimate is 3 percentage points below the measured one; measured number inside the range.
By their numbers in this assay, from the lowest: compound 1; then compound 4; then compounds 3 and 2 (each within the scatter of the next).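

Going by these compounds alone, at this place, on a saturated chain carbon bound to an aromatic nitrogen, the only matched change gives a large step in this assay: a number 45 percentage points lower from compound 2 to compound 4 (beyond the scatter). The 1-carboxyethyl group is therefore not required for a substantial share of the oral dose to reach the circulation, since compound 4 with 1,2-dihydroxyethyl still gives 63%. Nothing at hand accounts for the step.

Going by these compounds, whether the same change gives a similar step on the core of compound 3 remains open. So does how a primary amine, an amide or a longer chain would read at this place.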